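The source may hold more compounds than are shown below. What is called first, only, known or untested is meant among the compounds shown, and "the series" means these compounds.

Working notes on the series. In a functional assay on HL-60 cells (Homo sapiens) for antiproliferative activity, read by MTT assay, tested at 100 ug/mL (a lower number here means less inhibition, a higher number more inhibition at the concentration tested (going by the name of the read-out)), compound 1, `O=C1CCCCC1S(=O)(=O)Nc1ccc(Cl)cc1C(F)(F)F`, gives 78.6%. Compound 2, `O=C1CCCCC1S(=O)(=O)Nc1ccc(Cl)cc1`, gives -13% in this assay; the change from compound 1 is hydrogen in place of trifluoromethyl on an aromatic carbon, and the step is a number 91.6 percentage points lower from compound 1 to compound 2 (beyond the scatter). Going by the values given here, compound 2 therefore stands lowest of the two numbers measured so far, with compound 1 the only neighbour and far above it.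

The next compound is compound 3, `O=C1CCCCC1S(=O)(=O)Nc1ccc(Cl)c(Cl)c1`, which differs from compound 2 by chloro in place of hydrogen on an aromatic carbon. Among the compounds with values here, only one measured step exists, and it concerns a different position and a different group, so it bears on the new change only loosely: it shows that what sits on the aromatic ring of the shared core can move this assay strongly, as in compound 1 with 78.6% against compound 2 with -13%. Within the data shown here, no measured step tells whether a chloro entering at this carbon restores inhibition. The expected step from compound 2 to compound 3 is a moderate rise, a number 28 percentage points higher from compound 2 to compound 3 (beyond the scatter), with wide uncertainty. Compound 3 is estimated at 15%, within -15% to 55%.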

Compound 3, a percentage reported as inhibition, at one concentration (the size of the read-out at that concentration, not a potency): 13.5%
Estimate against measurement, compound 3: 1.5 percentage points above; measured number inside the range.
By their numbers in this assay, from the lowest: compound 2; then compound 3; then compound 1.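

Chloro in place of hydrogen on this aromatic carbon, ortho to a chloro group and meta to a large group, gives a step of its own in this assay: a number 26.5 percentage points higher from compound 2 to compound 3 (beyond the scatter). Going by these compounds alone, this is the first measured sign that this carbon also responds to substitution, since the earlier step concerned only hydrogen in place of trifluoromethyl at a different place on the ring. The change is printed as modest, and compound 3 stays at 13.5%, so a chloro entering here lifts the number clear of the scatter but yields only low inhibition at the concentration tested, and no measurement at hand accounts for the step.

The compounds shown leave open whether the rise belongs to chloro specifically or would also follow from another group at this carbon, such as a methoxy group, an amine or a carboxylic acid. They also leave open how a group entering at this carbon would act in the presence of the trifluoromethyl of compound 1, as that combination does not stand among them.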